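This account rests on a few compounds, and the source may have more. Where it says the series, first, only, none or still open, it means among the compounds named here.

Working notes on the series

Compound 1 `C=C(Cl)C(=O)Nc1cc(Nc2nccc(-c3cn(C)c4ccccc34)n2)c(OC)cc1N(C)CCN(C)C` carries the shared core with a 1-chloroethenyl carbonyl amide. In a functional assay on NCI-H1975 cells (Homo sapiens) for antiproliferative activity, read by sulforhodamine B assay, with a stated time of 72 h (a higher number here means a weaker inhibitor, a lower number a stronger inhibitor), compound 1 gives 241 nM. Among the compounds with values here, of the two numbers so far, compound 1 sits nearest to compound 2 `C=C(F)C(=O)Nc1cc(Nc2nccc(-c3cn(C)c4ccccc34)n2)c(OC)cc1N(C)CCN(C)C`, which in this assay gives 208 nM; the step of a 1.2-fold lower number from compound 1 to compound 2 (0.06 log units; within the scatter), fluoro in place of chloro on a double-bonded chain carbon bound to a carbonyl carbon, leaves the two compounds indistinguishable within the scatter.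

Compound 3 `C=C(C)C(=O)Nc1cc(Nc2nccc(-c3cn(C)c4ccccc34)n2)c(OC)cc1N(C)CCN(C)C` is the next member. Its difference from compound 1 is methyl in place of chloro on a double-bonded chain carbon bound to a carbonyl carbon. Within the data shown here, the only measured step at the same place, from compound 1 to compound 2, exchanges one halogen for another and stays within the scatter, so it bears on the present change only loosely: methyl is not a halogen, and no measured step covers that exchange. Carrying the small size of a 1.2-fold lower number from compound 1 to compound 2 (0.06 log units; within the scatter) forward while allowing for the untested nature of methyl, compound 3 is expected to lie somewhat weaker than compound 1 in this assay, with a step of a 2.9-fold higher number from compound 1 to compound 3 (0.46 log units; beyond the scatter). The estimate for compound 3 in this assay is therefore 700 nM, with a range from 250 nM to 2500 nM.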

Compound 3, half-maximal inhibitory concentration: 486 nM
Beside the measured number, compound 3's estimate is 1.4-fold (0.16 log units) above it; the range from low to high includes it.
By their numbers in this assay, from the lowest: compounds 2, 1 and 3 (each within the scatter of the next, the first and the last beyond it).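

In this assay, within the data shown here, the place on a double-bonded chain carbon bound to a carbonyl carbon now carries a group other than a halogen, and methyl in place of fluoro gives the first step at this place that lies beyond the scatter: a 2.3-fold higher number from compound 2 to compound 3 (0.37 log units; beyond the scatter). The other exchange, methyl in place of chloro, gives a 2.0-fold higher number from compound 1 to compound 3 (0.30 log units; within the scatter), so the 1-methylethenyl amide can be told apart from only one of the two halogen-bearing compounds, and the size of the effect of this change depends on which halogen it replaces. Nothing in the data on hand accounts for either step or says what separates methyl from the two halogens at this place.

On these data alone, the three groups compared here are all single-atom or single-carbon substituents, so it remains open how this place would read with hydrogen alone, with trifluoromethyl, or with a longer chain such as ethyl. A dimethylaminomethyl group at the same place would show whether an amine is tolerated there, and only such further exchanges could show whether the modest spread seen so far holds for larger groups.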